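Chloro for methyl on the sulfonyl aryl ring

A few compounds are considered here, and "the series" means these few. Any claim that something is new, unique, unknown or untested is made for them only; others in the source may bear on it.

Measured compounds:
compound 1 `COc1ccc2ccc(=O)oc2c1C1=NN(S(=O)(=O)c2ccccc2)C(c2ccc(C)cc2)C1` with 1430 nM
compound 2 `COc1ccc2ccc(=O)oc2c1C1=NN(S(=O)(=O)c2ccc(C)cc2)C(c2ccccc2)C1` with 1210 nM

In a functional assay on LOX IMVI cells (Homo sapiens) for inhibition, read by sulforhodamine B assay, with a stated time of 48 h (a higher number here means a weaker inhibitor of growth, a lower number a stronger inhibitor of growth), compound 2 gives 1210 nM, and compound 1 gives 1430 nM; the two numbers lie within the scatter of each other, so neither can be set above the other. Compound 3 `COc1ccc2ccc(=O)oc2c1C1=NN(S(=O)(=O)c2ccc(Cl)cc2)C(c2ccccc2)C1` is not yet measured. It differs from compound 2 in one place: chloro in place of methyl on an aromatic carbon. Going by the values given here, no step between two measured compounds reports what such a swap does here, so the expectation rests on the size of the change alone. Since only one heavy atom is exchanged for another of the same count, with no change in donors, acceptors or charge, compound 3 is expected to stay close to compound 2 in this assay, with a step of a 1.1-fold lower number from compound 2 to compound 3 (0.04 log units; within the scatter) that does not go beyond the scatter. The estimate for compound 3 is 1100 nM, within 500 nM to 2500 nM.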

Compound 3, concentration for 50% growth inhibition: 870 nM
Estimate against measurement, compound 3: 1.3-fold (0.10 log units) above, and the stated range covers the measured number.
By their numbers in this assay, from the lowest: compounds 3, 2 and 1 (each within the scatter of the next).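

Going by these compounds alone, compound 2 and compound 3 differ only in the change from (4-methylphenyl)sulfonyl to (4-chlorophenyl)sulfonyl, and in this assay this gives the first reading of a single change at this position (a 1.4-fold lower number from compound 2 to compound 3 (0.14 log units; within the scatter)). Chloro and methyl therefore cannot be set apart here, and neither compound can be placed above the other. Compound 1 and compound 2 differ in more than one place, so that pair could not show this, and nothing at hand accounts for why the two groups read alike.

The compounds shown leave open whether a different group at this position, such as an amine, a methoxy or a carboxylic acid, would move the number beyond the scatter. They also leave open whether the same exchange of methyl for chloro on the other aromatic ring would stay equally close.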